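Heteroaryl variation on the oxygen-bearing saturated carbon

The source may report more compounds than this note shows. Statements on the series, on what has been measured and on what is new or still open speak of the compounds shown alone.

Three members of the series have been measured in a functional assay on Jurkat cells (Homo sapiens) for inhibition; on this read-out higher numbers stand for weaker inhibition and lower numbers for stronger inhibition. Compound 1 `CC(C)[C@H](NC(=O)COc1cccc2ccccc12)C(=O)N[C@@H](CC(=O)O)C(=O)CSc1nc2ccccc2[nH]1` returns only a limit, > 200000 nM. Compound 2 `CC(C)[C@H](NC(=O)COc1cccc2ccccc12)C(=O)N[C@@H](CC(=O)O)C(=O)COc1ccccn1` likewise gives only a limit in this assay, > 200000 nM. Compound 3 `Cc1cc(OCC(=O)[C@H](CC(=O)O)NC(=O)[C@@H](NC(=O)COc2cccc3ccccc23)C(C)C)nc(C)n1`, the parent of the step followed here, also reaches only a limit in this assay, > 200000 nM. All three readings sit at the limit of > 200000 nM in this assay, at which 3 of the 3 values shown sit, so none of the steps among them can be sized: a step that the two limits leave unreadable from compound 1 to compound 2, a step that the two limits leave unreadable from compound 1 to compound 3, a step that the two limits leave unreadable from compound 2 to compound 3.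

Compound 4 `CC(C)[C@H](NC(=O)COc1cccc2ccccc12)C(=O)N[C@@H](CC(=O)O)C(=O)COc1nccc(C(F)(F)F)n1` has not been measured. It differs from compound 3 in one place: 4-(trifluoromethyl)pyrimidin-2-yl in place of 2,6-dimethylpyrimidin-4-yl on an oxygen on a saturated carbon. The three measured steps all exchange the group on the same oxygen-bearing saturated carbon, and all stay unreadable between limits, so they give no direction or size for the change to compound 4. Because compound 3 and both other measured compounds sit at the limit of > 200000 nM in this assay, at which 3 of the 3 values shown sit, the expectation is that compound 4 also gives no readable inhibition in this assay, with the step estimated as a number no higher from compound 3 to compound 4 (the limit leaves the size open). Compound 4 is accordingly expected at 200000 nM, within 60000 nM to 700000 nM.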

Compound 4, half-maximal inhibitory concentration: > 200000 nM
Compound 4: only a limit was reported (the forecaster's own chance of this, stated with the estimate: 85%); the middle value sits exactly at the limit.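

Compound 4 gives > 200000 nM in this assay, again only a limit. The steps to compound 4 from compound 1, compound 2 and compound 3 therefore cannot be read: the limit of > 200000 nM in this assay, at which 4 of the 4 values shown sit.

The compounds shown leave open whether any of these exchanged groups changes inhibition in this assay, and in which direction or by how much.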